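Amide aryl ring variation on the shared core

The source may hold more compounds than are shown below. What is called first, only, known or untested is meant among the compounds shown, and "the series" means these compounds.

Among the compounds with values here, compound 2 `O=C(Nc1cc(-c2ccccc2)nn1-c1ccccc1)c1cccc(F)c1` gives 20 nM in an assay on CHO cells with metabotropic glutamate receptor 5 (Homo sapiens) as the target (on this read-out lower numbers stand for an effect already at smaller amounts and higher numbers for an effect only at larger amounts of compound), and stands as the lowest of the two numbers measured so far. Within the data shown here, the only comparator is compound 1 `O=C(Nc1cc(-c2ccccc2)nn1-c1ccccc1)c1ccccc1F`, which in this assay gives 75 nM; the two are separated by a 3.8-fold lower number from compound 1 to compound 2 (0.57 log units; beyond the scatter). Compound 3 `O=C(Nc1cc(-c2ccccc2)nn1-c1ccccc1)c1ccccc1O` has not yet been measured. Its difference from compound 2 is 2-hydroxyphenyl in place of 3-fluorophenyl on a carbonyl carbon. Among the measured compounds shown here, no measured pair covers an exchange of fluorine for hydroxyl on this ring, so the step from compound 1 to compound 2 is the only one that bears on the change, and only in part: the 2-fluorophenyl arrangement of compound 1 gave the higher number, and compound 3 returns the substituent to that arrangement while also changing its identity. For the measured compounds named here, the number for compound 3 is therefore expected to rise relative to compound 2 by roughly the size of that step, with a wide range, since the hydroxyl has no precedent in this pair. Compound 3 is estimated at 80 nM in this assay, with a range of 20 nM to 320 nM. The expected step is a 4.0-fold higher number from compound 2 to compound 3 (0.60 log units; beyond the scatter).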

Compound 3, half-maximal effective concentration: > 10000 nM
Compound 3 was reported as a limit (the forecaster's own chance of this, stated with the estimate: 5%); middle value at least 120-fold (2.09 log units) from the limit.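

Notes on the amide aryl ring: in this assay, 2-hydroxyphenyl in place of 3-fluorophenyl on a carbonyl carbon gives an at least 500-fold higher number from compound 2 to compound 3 (2.69 log units; beyond the scatter), and hydroxy in place of fluoro on an aromatic carbon gives an at least 130-fold higher number from compound 1 to compound 3 (2.12 log units; beyond the scatter). The second change replaces only the substituent, and its step far exceeds a 3.8-fold lower number from compound 1 to compound 2 (0.57 log units; beyond the scatter), so across these three compounds the identity of the substituent on this ring counts for much more than the difference between the 2-fluorophenyl and 3-fluorophenyl arrangements. Compound 3 is reported as a limit and not a number, so both new steps are bounds only: the limit of > 10000 nM in this assay, at which 1 of the 3 values shown sits.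

The compounds shown leave open whether this loss belongs to hydroxy specifically or would also appear with other groups in the same place, such as methoxy or amino. They also leave open whether 3-hydroxyphenyl, which would keep the arrangement of compound 2 and change only the substituent, would show a loss of the same size.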